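Swapping chloro for methyl on the pyridine ether of compound 3

The compounds below may be only part of what the source reports. "The series", "measured", "known", "first", "only" and "open" are said of these compounds alone.

Of the compounds shown here, three built on the same core have been measured in an ADME assay on PBMC cells (Homo sapiens) for cytotoxicity; on this read-out higher numbers stand for lower toxicity in this test and lower numbers for higher toxicity in this test. Compound 1 `CC(CCNC(=O)c1c(Cl)cncc1Cl)N1CCC(C(Oc2cccc(C(F)(F)F)c2)c2ccc(C(F)(F)F)cc2)CC1` gives 7000 nM. Compound 2 `CC(CCNC(=O)c1c(Cl)cncc1Cl)N1CCC(C(Oc2ccccn2)c2ccc(C(F)(F)F)cc2)CC1` gives 34100 nM. Compound 3 `CC(CCNC(=O)c1c(Cl)cncc1Cl)N1CCC(C(Oc2ncccc2Cl)c2ccc(C(F)(F)F)cc2)CC1` gives 16700 nM, the second highest of the three numbers; it sits a 2.0-fold lower number from compound 2 to compound 3 (0.31 log units; beyond the scatter) and a 2.4-fold higher number from compound 1 to compound 3 (0.38 log units; beyond the scatter). The remaining step, a 4.9-fold higher number from compound 1 to compound 2 (0.69 log units; beyond the scatter), shows that replacing the aryl ether of compound 1 matters modestly in this assay.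

Compound 4 `Cc1cccnc1OC(c1ccc(C(F)(F)F)cc1)C1CCN(C(C)CCNC(=O)c2c(Cl)cncc2Cl)CC1` has not yet been measured. It differs from compound 3 in one place: methyl in place of chloro on an aromatic carbon. Among the measured compounds shown here, the only measured step touching this position is a 2.0-fold lower number from compound 2 to compound 3 (0.31 log units; beyond the scatter), a modest move when chloro entered for hydrogen. For the measured compounds named here, no measured step replaces chloro with methyl, so the direction is uncertain, and the size is expected to stay near the scatter.

Compound 4 is therefore estimated at 18000 nM, within 8000 nM to 40000 nM, which is expected to read as a 1.1-fold higher number from compound 3 to compound 4 (0.03 log units; within the scatter).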

Compound 4, half-maximal cytotoxic concentration: 33000 nM
Compound 4: the middle estimate sits 1.8-fold (0.26 log units) below what was measured; the range from low to high includes it.
By their numbers in this assay, from the lowest: compound 1; then compounds 3, 4 and 2 (each within the scatter of the next, the first and the last beyond it).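

In this assay, putting a methyl group on this aromatic carbon gives a number that cannot be told apart from that of the chloro compound (a 2.0-fold higher number from compound 3 to compound 4 (0.30 log units; within the scatter)) or the unsubstituted pyridine (a 1.0-fold lower number from compound 2 to compound 4 (0.01 log units; within the scatter)), even though those two compounds lie just beyond the scatter of each other. Compound 4 also keeps the distance from compound 1 (a 4.7-fold higher number from compound 1 to compound 4 (0.67 log units; beyond the scatter)), so 3-methylpyridin-2-yl joins pyridin-2-yl and 3-chloropyridin-2-yl in reading higher than 3-(trifluoromethyl)phenyl. No available evidence explains why methyl reads as it does here.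

As far as these compounds go, it remains open how a methoxy group, an amine or a carboxylic acid on this same carbon would read. The compounds shown also leave open whether a longer chain such as ethyl would stay close to methyl.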